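Series notes: carboxy on the benzyl group, cytotoxicity

The compounds below may be only part of what the source reports. "The series", "measured", "known", "first", "only" and "open" are said of these compounds alone.

Measured so far in an ADME assay on MT2 cells (Homo sapiens) for cytotoxicity, read by XTT assay, with a stated time of 4 days; on this read-out lower numbers stand for higher toxicity in this test and higher numbers for lower toxicity in this test:
compound 1 `Cc1cc(/C=C2\SC(=S)N(c3ccccc3)C2=O)c(C)n1-c1ccc(O)c(C(=O)O)c1` gives > 100000 nM, which is a limit of the test and not a number.
compound 2 `Cc1cc(/C=C2\SC(=S)N(Cc3ccccc3)C2=O)c(C)n1-c1ccc(O)c(C(=O)O)c1` gives 159000 nM.
compound 3 `COC(=O)c1ccc(CN2C(=O)/C(=C/c3cc(C)n(-c4ccc(O)c(C(=O)O)c4)c3C)SC2=S)cc1` gives 36900 nM.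

Among the two numbers, compound 2 stands highest; its nearest neighbour is compound 3, with a 4.3-fold lower number from compound 2 to compound 3 (0.63 log units; beyond the scatter). The third value is the limit (the limit of > 100000 nM in this assay, at which 1 of the 3 values shown sits), so the step that the limit leaves unreadable from compound 1 to compound 2 and the step of an at least 2.7-fold lower number from compound 1 to compound 3 (0.43 log units; beyond the scatter) can only be read in part.

Compound 4 `Cc1cc(/C=C2\SC(=S)N(Cc3cccc(C(=O)O)c3)C2=O)c(C)n1-c1ccc(O)c(C(=O)O)c1` is not yet measured. It differs from compound 2 by carboxy in place of hydrogen on an aromatic carbon. Going by the values given here, the one measured step that bears on this change is a 4.3-fold lower number from compound 2 to compound 3 (0.63 log units; beyond the scatter), where a methoxycarbonyl enters on the same benzyl ring. Among the compounds with values here, a carboxy entering on that ring is the closest comparison available, and a step of similar direction, though possibly smaller, is expected for compound 4; no measured step speaks for a rise in the number. The expected step is therefore a 2.3-fold lower number from compound 2 to compound 4 (0.36 log units; beyond the scatter), a modest fall in the number that is beyond the scatter but not firmly so.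

The estimate for compound 4 in this assay is 70000 nM, with a range from 25000 nM to 200000 nM.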

Compound 4, half-maximal cytotoxic concentration: > 100000 nM
Compound 4: a limit, no number; the forecaster's own chance of this, stated with the estimate: 25%; at least 1.4-fold (0.15 log units) between middle value and limit.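

In this assay compound 4 gives > 100000 nM, which is a limit of the test and not a number. Going by these compounds alone, the one readable step is an at least 2.7-fold higher number from compound 3 to compound 4 (0.43 log units; beyond the scatter), so the 3-carboxybenzyl group does not reproduce the low number seen with the methoxycarbonyl-bearing benzyl group of compound 3, and the fall that accompanied methoxycarbonyl on this ring does not carry over to carboxy at the position meta to the large group. The steps to compound 4 from compound 1 and from compound 2 cannot be read, so the size and direction of the change from hydrogen to carboxy on this ring remain unknown, because the values concerned sit at the ceiling of the test: the limit of > 100000 nM in this assay, at which 2 of the 4 values shown sit.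

The step from compound 3 to compound 4 changes both the group and its place on the ring, which leaves open whether the group or its place goes with the higher number; a carboxy at the ring place of the methoxycarbonyl in compound 3, or a methoxycarbonyl at the ring place of the carboxy in compound 4, would separate the two. Also open, as far as these compounds go, is how an amine on the same benzyl ring would read in this assay.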